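This account rests on a few compounds, and the source may have more. Where it says the series, first, only, none or still open, it means among the compounds named here.

Of the compounds shown here, three sharing one core have been measured in an ADME assay on SH-SY5Y cells (Homo sapiens) for cytotoxicity, read by MTT assay, with a stated time of 72 h; on this read-out lower numbers stand for stronger inhibition and higher numbers for weaker inhibition. Compound 1 `COc1ccc(C(=O)N2CCN(CC(=O)N3CCN(CCCc4c[nH]c5ccc(F)cc45)CC3)CC2)cc1` gives 161000 nM, compound 2 `O=C(CN1CCN(C(=O)c2ccc(F)cc2)CC1)N1CCN(CCCc2c[nH]c3ccc(F)cc23)CC1` gives 121000 nM, and compound 3 `O=C(CN1CCN(C(=O)c2cccc(Cl)c2)CC1)N1CCN(CCCc2c[nH]c3ccc(F)cc23)CC1` gives 59800 nM. Compound 3 therefore holds the lowest number of the three. Its gaps to the other two lie beyond the scatter, but both are modest: a 2.0-fold lower number from compound 2 to compound 3 (0.31 log units; beyond the scatter) and a 2.7-fold lower number from compound 1 to compound 3 (0.43 log units; beyond the scatter).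

Compound 4 `COc1ccc2[nH]cc(CCCN3CCN(C(=O)CN4CCN(C(=O)c5cccc(Cl)c5)CC4)CC3)c2c1` keeps all of compound 3 except one group, with methoxy in place of fluoro on an aromatic carbon, so that 5-fluoro-1H-indol-3-yl becomes 5-methoxy-1H-indol-3-yl (methoxy in place of fluoro on an aromatic carbon). The nearest evidence is the same pair of groups exchanged the other way round, on the phenyl group attached to a carbonyl carbon: a 1.3-fold lower number from compound 1 to compound 2 (0.12 log units; within the scatter), a step within the scatter. For the measured compounds named here, no measured pair shows this exchange on the fused ring system itself, so that single step is only a loose guide. Read in reverse, it points to a slightly higher number in this assay, if to any change at all. The expected size is small, a 1.2-fold higher number from compound 3 to compound 4 (0.07 log units; within the scatter), and is not expected to clear the scatter. For compound 4 the estimated value is 70000 nM, with an expected range from 35000 nM to 140000 nM.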

Compound 4, half-maximal inhibitory concentration: > 200000 nM
Compound 4 ended at the assay's limit; the forecaster's own chance of this, stated with the estimate: 5%; middle value at least 2.8-fold (0.45 log units) from the limit.
By their numbers in this assay, from the lowest: compound 3; then compounds 2 and 1 (each within the scatter of the next). At a limit, above all of these: compound 4.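

For the compounds shown here, replacing 5-fluoro-1H-indol-3-yl with 5-methoxy-1H-indol-3-yl gives the first direct reading of this position in this assay, and the number moves beyond the scatter (an at least 3.3-fold higher number from compound 3 to compound 4 (0.52 log units; beyond the scatter)). Compound 4 gives > 200000 nM, which is a limit of the assay and not a number. The earlier comparison of compound 1 with compound 2 placed the same exchange on a phenyl group attached to a carbonyl carbon, and its step stayed within the scatter, so that result cannot stand in for this position, although the two steps cannot be shown to differ: the same change on two cores in this assay, a 1.3-fold lower number (0.12 log units; within the scatter) from compound 1 to compound 2 and an at least 3.3-fold lower number (0.52 log units; beyond the scatter) from compound 4 to compound 3; the limit leaves it open whether they differ.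

From the compounds shown here alone, the full size of the step from compound 3 to compound 4 stays open, as does whether the same exchange at this position would give a similar result with a different group on the carbonyl carbon. The compounds shown also leave open what a hydroxy group, a chlorine atom or an amine would do on this aromatic carbon, and so whether the higher number is particular to methoxy.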